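This account rests on a few compounds, and the source may have more. Where it says the series, first, only, none or still open, it means among the compounds named here.

Measured in a functional assay on the whole organism with Mus musculus as the target; a higher number here means that more compound is needed for the effect, a lower number that less compound is needed:

- compound 1 `CNC(=O)/C=C(\C)c1cccc(C(F)(F)F)c1` gives > 100 mg/kg (a limit)
- compound 2 `CN1C(=O)CCC1(O)c1cccc(C(F)(F)F)c1` gives 133 mg/kg
- compound 3 `CN(C)C(=O)CCC(=O)c1cccc(C(F)(F)F)c1` gives > 50 mg/kg (a limit)

Only compound 2 has a true number in this set. Compound 3 stands at > 50 mg/kg, and this is a limit, not a number. Compound 1 also stands at a limit, so the figures do not place compound 3 in an order with the other two.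

The next compound, compound 4 `CN1CCN(C(=O)CCC(=O)c2cccc(C(F)(F)F)c2)CC1`, carries 4-methylpiperazin-1-yl in place of dimethylamino on a carbonyl carbon. Among the measured compounds shown here, no measured step shows what such a change does, so no step beyond the usual scatter is expected, and its direction stays open. The expected change is a step that the limit leaves unreadable from compound 3 to compound 4, an estimate set against a limit. The expected level also leans on compound 2 at 133 mg/kg. For compound 4 the estimated dose is 90 mg/kg, with an expected range from 35 mg/kg to 220 mg/kg.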

Compound 4, dose for half-maximal effect: > 50 mg/kg
Compound 4: no number, only a limit; the forecaster's own chance of this, stated with the estimate: 50%; the middle value is on the limit's open side.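

Compound 3 gives > 50 mg/kg, which is a limit. Among the compounds shown here, compound 4 gives > 50 mg/kg, also a limit, and no step between compound 3 and compound 4 can be read. The compounds shown leave open whether 4-methylpiperazin-1-yl in place of dimethylamino on a carbonyl carbon changes the dose at all, and in which direction.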